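A Trifluoromethyl for Chloro Swap Weighed Against Earlier Steps

The source may report more compounds than this note shows. Statements on the series, on what has been measured and on what is new or still open speak of the compounds shown alone.

Compound 2 `O=C(Nc1cccc(-n2cc(-c3ccncc3)c(-c3ccc(Cl)c(O)c3)n2)c1)Nc1ccc(Cl)c(Cl)c1` gives 1550 nM in a functional assay on T47D cells (Homo sapiens) for inhibition, read by sulforhodamine B assay, with a stated time of 48 h; on this read-out higher numbers stand for weaker inhibition of growth and lower numbers for stronger inhibition of growth. Its neighbours are compound 1 `COc1cc(-c2nn(-c3cccc(NC(=O)Nc4ccc(Cl)c(Cl)c4)c3)cc2-c2ccncc2)ccc1Cl`, which gives 1420 nM in this assay, and compound 3 `COc1cc(-c2nn(-c3cccc(NC(=O)c4ccccc4)c3)cc2-c2ccncc2)ccc1Cl`, which gives 1900 nM. Compound 2 thus holds the second highest of the three numbers, with compound 1 nearest and compound 3 furthest, and both gaps fall within the scatter. The two measured steps, a 1.1-fold higher number from compound 1 to compound 2 (0.04 log units; within the scatter) and a 1.3-fold higher number from compound 1 to compound 3 (0.13 log units; within the scatter), are likewise within the scatter.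

Compound 4 `O=C(Nc1cccc(-n2cc(-c3ccncc3)c(-c3ccc(Cl)c(O)c3)n2)c1)Nc1ccc(Cl)c(C(F)(F)F)c1` differs from compound 2 by trifluoromethyl in place of chloro on an aromatic carbon. Within the data shown here, no measured step touches this exact position. The step from compound 1 to compound 3, a 1.3-fold higher number from compound 1 to compound 3 (0.13 log units; within the scatter), replaced the whole (3,4-dichlorophenyl)amino group and still stayed within the scatter, and the step at the oxygen, a 1.1-fold higher number from compound 1 to compound 2 (0.04 log units; within the scatter), was also flat. On that basis the expected step for compound 4 in this assay is a 1.0-fold lower number from compound 2 to compound 4 (0.01 log units; within the scatter), that is, nothing beyond the scatter in either direction. Compound 4 is therefore estimated at 1500 nM in this assay, with a range from 700 nM to 3200 nM.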

Compound 4, concentration for 50% growth inhibition: 1120 nM
Compound 4: the middle estimate sits 1.3-fold (0.13 log units) above what was measured; the range from low to high includes it.
By their numbers in this assay, from the lowest: compounds 4, 1, 2 and 3 (each within the scatter of the next).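

In this assay, among these compounds, the swap gave a 1.4-fold lower number from compound 2 to compound 4 (0.14 log units; within the scatter), and this is the first reading taken at this carbon itself: the earlier steps changed the group on the oxygen or replaced the whole (3,4-dichlorophenyl)amino group, whereas here the rest of that group stays in place and only one chloro is exchanged. It shows that going from 3,4-dichlorophenyl to 4-chloro-3-(trifluoromethyl)phenyl, with a chloro of 1 heavy atom giving way to a trifluoromethyl of 4 heavy atoms ortho to a chloro group, moves the number by no more than the scatter, so this position accepts the exchange without a readable change in growth inhibition. Nothing available here accounts for this result through any property of either group.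

As far as these compounds go, it remains open whether the same carbon would stay as flat with a group of another kind, such as a nitrile, an amine or a carboxylic acid. From the compounds shown here alone, it is also open whether the trifluoromethyl would read the same way with the methyl on the oxygen, as in compound 1, or on the phenyl amide of compound 3, and what a change at the remaining chloro of compound 4 would do.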